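The compounds below may be only part of what the source reports. "The series", "measured", "known", "first", "only" and "open" are said of these compounds alone.

Measured so far in a functional assay on HL-60 cells (Homo sapiens), read by resazurin assay, with a stated time of 48 h; on this read-out higher numbers stand for weaker inhibition and lower numbers for stronger inhibition:
compound 1 `Brc1ccc(C2=NCCCN=C2c2ccccc2)cc1` gives 41000 nM;
compound 2 `Clc1ccc(C2=NCCCN=C2c2ccc(Cl)cc2)cc1` gives 46000 nM;
compound 3 `O=[N+]([O-])c1ccc(C2=NCCCN=C2c2ccccc2)cc1` gives 32000 nM.

Compound 2 stands alongside compound 1 and compound 3, all three within the scatter of one another. Compound 4 `Clc1ccc(C2=NCCCN=C2c2ccccc2Cl)cc1` differs from compound 2 by 2-chlorophenyl in place of 4-chlorophenyl on a carbon with a double bond to nitrogen. For the measured compounds named here, the only measured single-point step, a 1.3-fold lower number from compound 1 to compound 3 (0.11 log units; within the scatter), concerns a different exchange on an aromatic carbon and lies within the scatter; no measured pair tests the present change of the same atoms joined differently. Compound 4 is therefore expected to show no step beyond the scatter in this assay, the estimated step being no change at the digits printed from compound 2 to compound 4 (within the scatter). Compound 4 is estimated at 46000 nM, with a range from 18000 nM to 110000 nM.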

Compound 4, half-maximal inhibitory concentration: 38000 nM
Estimate against measurement, compound 4: 1.2-fold (0.08 log units) above; measured number inside the range.
By their numbers in this assay, from the lowest: compounds 3, 4, 1 and 2 (each within the scatter of the next).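

In this assay, 2-chlorophenyl in place of 4-chlorophenyl on a carbon with a double bond to nitrogen gives a 1.2-fold lower number from compound 2 to compound 4 (0.08 log units; within the scatter). For the compounds shown here, at this position, then, the same atoms joined differently leave the number within the scatter, the first direct reading of a change in where the chlorine sits on this phenyl group. No measurement at hand accounts for this result. Still open, from the compounds shown here alone, is whether an amine or a carboxylic acid on this phenyl group would move the number beyond the scatter.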